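A few compounds are considered here, and "the series" means these few. Any claim that something is new, unique, unknown or untested is made for them only; others in the source may bear on it.

Of the compounds shown here, two sharing one core have been measured in a functional assay on TK-10 cells (Homo sapiens) for inhibition, read by sulforhodamine B assay, with a stated time of 48 h; a lower number here means a stronger inhibitor of growth, a higher number a weaker inhibitor of growth. Compound 1 `COc1cc2cc(Oc3ccc(NC(=O)Nc4cccc(C(F)(F)F)c4)cc3)c(C)nc2cc1OC` gives 2260 nM. Compound 2 `COc1cc2cc(Oc3ccc(NC(=O)Nc4ccc(Cl)c(C(F)(F)F)c4)cc3)c(C)nc2cc1OC` gives 1320 nM. The step of a 1.7-fold lower number from compound 1 to compound 2 (0.23 log units; within the scatter) is the only one recorded, so compound 2 shows the lower of the two numbers without standing apart from compound 1 beyond the scatter. Compound 3 `COc1cc2cc(Oc3ccc(NC(=O)Nc4ccc(Cl)c(Cl)c4)cc3)c(C)nc2cc1OC` follows from compound 2 by chloro in place of trifluoromethyl on an aromatic carbon. Among the compounds with values here, no measured step exchanges a trifluoromethyl for a chloro; the single step on record concerned a different group at another place and stayed within the scatter, which gives little ground for expecting a large move in this assay. A step of a 1.1-fold higher number from compound 2 to compound 3 (0.06 log units; within the scatter) is therefore expected, that is, no change beyond the scatter. Compound 3 is estimated at 1500 nM, with a range from 600 nM to 4000 nM.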

Compound 3, concentration for 50% growth inhibition: 3460 nM
Compound 3: the middle estimate sits 2.3-fold (0.36 log units) below what was measured; measured number inside the range.
By their numbers in this assay, from the lowest: compounds 2, 1 and 3 (each within the scatter of the next, the first and the last beyond it).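

In this assay, within the data shown here, chloro in place of trifluoromethyl, at this place ortho to a chloro group, gives the only step that passes the scatter (a 2.6-fold higher number from compound 2 to compound 3 (0.42 log units; beyond the scatter)), although it remains modest. With the other chloro present, the two groups therefore do not read alike here, whereas the comparison of the 3,4-dichlorophenyl with the 3-(trifluoromethyl)phenyl compound stays within the scatter (a 1.5-fold higher number from compound 1 to compound 3 (0.18 log units; within the scatter)), so that pair cannot be told apart. Nothing available explains the difference between trifluoromethyl and chloro at this position.

Still open, as far as these compounds go, is how a bromo or a nitrile at this place would compare with trifluoromethyl and chloro. From the compounds shown here alone, it is also open whether the same exchange would give a similar step on a ring carrying no other chloro.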